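Chloro Substitution on an Inactive Pair of Phenyl Compounds

The source may report more compounds than this note shows. Statements on the series, on what has been measured and on what is new or still open speak of the compounds shown alone.

Measured compounds:
- compound 1, `O=c1[nH]nc2n(c1=O)CCN2c1ccccc1`: 0%
- compound 2, `N/N=C1\NCCN1c1ccccc1`: 0%
- compound 3, `O=c1[nH]nc2n(c1=O)CCN2c1cccc(Cl)c1`: 0%

In a functional assay on T47D cells (Homo sapiens) for cytotoxicity, with a stated time of 72 h, tested at 10 ug/mL (a lower number here means a weaker effect, a higher number a stronger effect of the compound at the concentration tested), compound 1 gives 0%, compound 2 gives 0% and compound 3 gives 0%. Compound 3 arises from compound 1 by chloro in place of hydrogen on an aromatic carbon, and the step of no change at the digits printed from compound 1 to compound 3 (within the scatter). The difference between the cores of compound 1 and compound 2 is not broken down here.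

Compound 4, `N/N=C1\NCCN1c1cccc(Cl)c1`, is not yet measured. It arises from compound 2 by chloro in place of hydrogen on an aromatic carbon. This is the same kind of change as from compound 1 to compound 3, though the surroundings differ: in compound 4 the chloro sits meta to a group of 7 heavy atoms, in compound 3 meta to a large group.

Because no change at the digits printed from compound 1 to compound 3 (within the scatter), the expected step in this assay is no change at the digits printed from compound 2 to compound 4 (within the scatter). The estimate for compound 4 is 0%, expected between 0% and 10%.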

Compound 4, a percentage reported as inhibition, at one concentration (the size of the read-out at that concentration, not a potency): 5%
The estimate for compound 4 lay 5 percentage points below the measured number, within the range that was stated.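

In this assay, placing chloro on the aromatic ring of the second core gives a number 5 percentage points higher from compound 2 to compound 4 (within the scatter). Read side by side, the two steps agree, so this change carries over from one core to the other as far as this read-out can tell: the same change on two cores in this assay, no change at the digits printed (within the scatter) from compound 1 to compound 3 and a number 5 percentage points higher (within the scatter) from compound 2 to compound 4, 5 percentage points apart, within the scatter of two such steps This does not show that chloro has a real effect on either core, nor that the two cores would respond alike in a compound with clear activity, since neither step rises above the usual scatter.

The compounds shown leave open what a methoxy group, an amine or a carboxylic acid would do in place of the chloro on either core. They also leave open whether any such group would move the read-out clear of the scatter.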